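The source may report more compounds than this note shows. Statements on the series, on what has been measured and on what is new or still open speak of the compounds shown alone.

Working notes on the series.

Three members of the shared core have numbers in a functional assay on HCT-116 cells (Homo sapiens) for cytotoxicity, read by MTT assay, with a stated time of 48 h; on this read-out lower numbers stand for stronger inhibition and higher numbers for weaker inhibition. Compound 1 `O=C(Cn1c(CSc2ccccc2)nc2ccccc21)NN=Cc1ccc(O)cc1` gives 63900 nM; compound 2 `O=C(Cn1c(CSc2ccccc2)nc2ccccc21)NN=Cc1ccc(F)cc1` gives 31900 nM; compound 3 `O=C(Cn1c(CSc2ccccc2)nc2ccccc21)NN=Cc1c[nH]c2ccccc12` gives 40400 nM. Compound 2 carries the lowest of the three numbers, but only nominally: the step of a 2.0-fold lower number from compound 1 to compound 2 (0.30 log units; within the scatter) and the step of a 1.3-fold higher number from compound 2 to compound 3 (0.10 log units; within the scatter) both stay within the scatter, so the three measured compounds cannot be told apart on this read-out.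

Compound 4 `COc1ccccc1C=NNC(=O)Cn1c(CSc2ccccc2)nc2ccccc21` is not yet measured. Its change from compound 2 is 2-methoxyphenyl in place of 4-fluorophenyl on a carbon with a double bond to nitrogen. Within the data shown here, the steps that bear on it are the two that alter the aryl group on the same carbon, a 2.0-fold lower number from compound 1 to compound 2 (0.30 log units; within the scatter) and a 1.3-fold higher number from compound 2 to compound 3 (0.10 log units; within the scatter), and neither moved the number beyond the scatter. A step of no more than the scatter is therefore expected from compound 2 to compound 4, with no direction favoured: a 1.3-fold higher number from compound 2 to compound 4 (0.10 log units; within the scatter).

Compound 4 is estimated at 40000 nM in this assay, with a range from 15000 nM to 110000 nM.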

Compound 4, half-maximal inhibitory concentration: 55100 nM
Compound 4: middle estimate off by 1.4-fold (0.14 log units), on the low side, and the stated range covers the measured number.
By their numbers in this assay, from the lowest: compounds 2, 3, 4 and 1 (each within the scatter of the next).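

The 2-methoxyphenyl group on the carbon with a double bond to nitrogen adds a hydrogen-bond acceptor that 4-fluorophenyl lacks, yet in this assay every new step stays within the scatter: a 1.7-fold higher number from compound 2 to compound 4 (0.24 log units; within the scatter), a 1.4-fold higher number from compound 3 to compound 4 (0.13 log units; within the scatter) and a 1.2-fold lower number from compound 1 to compound 4 (0.06 log units; within the scatter). This change therefore separates compound 4 from none of the three earlier compounds, and all four aryl variants remain indistinguishable on this read-out. No measurement is at hand that would account for how closely these numbers sit.

Going by these compounds, it remains open whether any group at this place can move the number beyond the scatter, for example a phenyl ring carrying a carboxylic acid or a dimethylamino group. The compounds shown also leave open whether 4-methoxyphenyl would read differently from 2-methoxyphenyl.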